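The compounds below may be only part of what the source reports. "The series", "measured", "known", "first", "only" and "open" are said of these compounds alone.

Compound 1 `CCCCNc1nc2cc(-c3ccc(C)cc3)sc2c(=O)[nH]1`: 6000 nM
Compound 2 `CCCCCCCNc1nc2cc(-c3ccc(C)cc3)sc2c(=O)[nH]1`: 6800 nM

In an ADME assay on HepG2 cells (Homo sapiens) for cytotoxicity, read by MTT assay, with a stated time of 72 h (a lower number here means that less compound is tolerated, a higher number that more compound is tolerated), compound 2 cannot be told apart from compound 1, since their two values lie within the usual scatter. Compound 3 `Cc1ccc(-c2cc3nc(NCC(C)C)[nH]c(=O)c3s2)cc1` is not yet measured and differs from compound 2 by isopropyl in place of hexyl on a saturated chain carbon bound to a nitrogen on an aromatic ring, which reads heptylamino to isobutylamino when cut one bond further out. For the measured compounds named here, only one measured step also alters this chain: a 1.1-fold higher number from compound 1 to compound 2 (0.05 log units; within the scatter). That step is small, so no step beyond the scatter is expected in this assay. The expected step is a 1.1-fold lower number from compound 2 to compound 3 (0.03 log units; within the scatter). Compound 3 is expected at about 6400 nM, with an estimated range of 3000 nM to 14000 nM.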

Compound 3, half-maximal cytotoxic concentration: 21600 nM
For compound 3 the middle estimate is 3.4-fold (0.53 log units) below the measured one, outside the stated range (above it).
By their numbers in this assay, from the lowest: compounds 1 and 2 (each within the scatter of the next); then compound 3.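

In this assay, the position on the saturated chain carbon bound to a nitrogen on an aromatic ring now proves able to shift the tolerated concentration: isopropyl in place of hexyl gives a 3.2-fold higher number from compound 2 to compound 3 (0.50 log units; beyond the scatter), and isopropyl in place of propyl gives a 3.6-fold higher number from compound 1 to compound 3 (0.56 log units; beyond the scatter). Both steps favour the branched chain, whereas the two straight chains could not be told apart. Nothing measured here explains this shift. Going by these compounds, whether branching holds the effect remains open, since a longer branched chain, a cyclohexyl ring or a terminal amine could separate branching from other features of the chain.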